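This account rests on a few compounds, and the source may have more. Where it says the series, first, only, none or still open, it means among the compounds named here.

In a functional assay on HepG2 cells (Homo sapiens) for antiproliferative activity, read by sulforhodamine B assay, with a stated time of 48 h (a higher number here means a weaker inhibitor, a lower number a stronger inhibitor), compound 3 `COc1ccc(/C=C/C(=O)C(=Cc2cc(OC)c(O)c(OC)c2)C(=O)/C=C/c2ccc(OC)cc2OC)c(OC)c1` gives 320 nM, compound 1 `COc1ccc(/C=C/C(=O)C(=Cc2ccc(O)c(OC)c2)C(=O)/C=C/c2ccc(OC)cc2OC)c(OC)c1` gives 510 nM and compound 2 `COc1ccc(/C=C/C(=O)C(=Cc2cc(Br)c(O)c(OC)c2)C(=O)/C=C/c2ccc(OC)cc2OC)c(OC)c1` gives 1190 nM. Compound 3 thus sits together with compound 1 at the low end of the three numbers. Only the bromo changes stand out: a 2.3-fold higher number from compound 1 to compound 2 (0.37 log units; beyond the scatter) and a 3.7-fold lower number from compound 2 to compound 3 (0.57 log units; beyond the scatter). Compound 4 `COc1ccc(/C=C/C(=O)C(=Cc2ccc(OC)c(O)c2)C(=O)/C=C/c2ccc(OC)cc2OC)c(OC)c1` differs from compound 3 on a double-bonded chain carbon bound to a double-bonded chain carbon: 3-hydroxy-4-methoxyphenyl in place of 4-hydroxy-3,5-dimethoxyphenyl on a double-bonded chain carbon bound to a double-bonded chain carbon. The nearest guide is the methoxy change in compound 3, a 1.6-fold lower number from compound 1 to compound 3 (0.20 log units; within the scatter). For the measured compounds named here, no measured step moves the hydroxy, so that part of the change remains untested. A modestly higher number, or none beyond the scatter, is therefore expected in this assay. The expected step is a 1.6-fold higher number from compound 3 to compound 4 (0.21 log units; within the scatter). For compound 4 the estimated value is 520 nM, with an expected range of 220 nM to 1200 nM.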

Compound 4, half-maximal inhibitory concentration: 390 nM
The estimate for compound 4 lay 1.3-fold (0.12 log units) above the measured number; measured number inside the range.
By their numbers in this assay, from the lowest: compounds 3, 4 and 1 (each within the scatter of the next); then compound 2.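

In this assay, for the compounds shown here, exchanging the places of hydroxy and methoxy, which no earlier step tested, stays within the scatter (a 1.3-fold lower number from compound 1 to compound 4 (0.12 log units; within the scatter)), and so does the change from the 4-hydroxy-3,5-dimethoxyphenyl group (a 1.2-fold higher number from compound 3 to compound 4 (0.09 log units; within the scatter)). The 3-bromo-4-hydroxy-5-methoxyphenyl group remains the one that stands apart (a 3.1-fold lower number from compound 2 to compound 4 (0.48 log units; beyond the scatter)). Nothing at hand explains these results.

Every group shown at this place carries both a hydroxy and a methoxy. As far as these compounds go, what an amine or a carboxylic acid in place of the hydroxy, or a longer chain in place of the methoxy, would do remains open.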